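Quinoline amides: difluoro to dichloro on the benzamide

The source may hold more compounds than are shown below. What is called first, only, known or untested is meant among the compounds shown, and "the series" means these compounds.

Measured compounds in a functional assay on MCF7 cells (Homo sapiens) for antiproliferative activity, read by MTT assay, with a stated time of 72 h; on this read-out higher numbers stand for weaker inhibition and lower numbers for stronger inhibition:

compound 1, `Cc1cc(NCCN(C)C)nc2ccc(NC(=O)c3ccc(Cl)c(Cl)c3)cc12`, 2550 nM
compound 2, `CCN1CCN(c2cc(C)c3cc(NC(=O)c4cc(Cl)cc(Cl)c4)ccc3n2)CC1`, 6090 nM
compound 3, `CCN1CCN(c2cc(C)c3cc(NC(=O)c4ccc(F)c(F)c4)ccc3n2)CC1`, 5230 nM

Compound 3 holds the second highest of the three numbers in this assay; its nearest neighbour is compound 2, within the scatter, and its furthest is compound 1, whose number is beyond the scatter below it. Among the compounds with values here, the one step with a single change, a 1.2-fold lower number from compound 2 to compound 3 (0.07 log units; within the scatter), stayed within the scatter.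

Compound 4, `CCN1CCN(c2cc(C)c3cc(NC(=O)c4ccc(Cl)c(Cl)c4)ccc3n2)CC1`, is not yet measured. It differs from compound 3 by 3,4-dichlorophenyl in place of 3,4-difluorophenyl on a carbonyl carbon. Within the data shown here, no measured step tests this exact exchange on the shared core. Among the measured compounds shown here, compound 1 carries the same 3,4-dichlorophenyl group but a different amine side chain, so its value gives no direct step. The exchange of one dihalogenated phenyl for another in a 1.2-fold lower number from compound 2 to compound 3 (0.07 log units; within the scatter) gave no change beyond the scatter, and a similar outcome is expected here, with perhaps a slight lowering of the number: the step of a 1.2-fold lower number from compound 3 to compound 4 (0.10 log units; within the scatter) is the expectation. Compound 4 is estimated at 4200 nM, between 1800 nM and 9500 nM.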

Compound 4, half-maximal inhibitory concentration: 1380 nM
Beside the measured number, compound 4's estimate is 3.0-fold (0.48 log units) above it; measured number below the stated range.
By their numbers in this assay, from the lowest: compounds 4 and 1 (each within the scatter of the next); then compounds 3 and 2 (each within the scatter of the next).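

With the 4-ethylpiperazin-1-yl side chain held, the earlier exchange of dihalogenated phenyl groups had stayed within the scatter, but in this assay 3,4-dichlorophenyl in place of 3,4-difluorophenyl on a carbonyl carbon gives a 3.8-fold lower number from compound 3 to compound 4 (0.58 log units; beyond the scatter) and so separates the two halogens at this position. Placement of the chlorines also counts here, as 3,4-dichlorophenyl in place of 3,5-dichlorophenyl gives a 4.4-fold lower number from compound 2 to compound 4 (0.64 log units; beyond the scatter) with the atom count of the group unchanged. The amine exchange, 4-ethylpiperazin-1-yl in place of (2-(dimethylamino)ethyl)amino, gives a 1.8-fold lower number from compound 1 to compound 4 (0.27 log units; within the scatter) and stays within the scatter with this aryl group.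

Nothing at hand accounts for these differences. Open too, from the compounds shown here alone, is how a mixed chloro-fluoro phenyl group would read on the carbonyl carbon, and whether a morpholine on the shared core would keep the number of compound 4.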